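The compounds below may be only part of what the source reports. "The series", "measured", "known", "first", "only" and "open" are said of these compounds alone.

Measured so far:
compound 1 `CCCOC(=O)c1ccc2[nH]c(NC(=O)OC)nc2c1`: 7400 nM in a functional assay on L1210 cells (Mus musculus) for inhibition; a higher number here means a weaker inhibitor, a lower number a stronger inhibitor
compound 2 `CCCOC(=O)Nc1nc2cc(C(=O)OCCC)ccc2[nH]1`: 8200 nM in this assay

Going by the values given here, compound 1 and compound 2 sit together: the single measured step, a 1.1-fold higher number from compound 1 to compound 2 (0.04 log units; within the scatter), is within the scatter, so nothing separates them, and compound 1 marks no more than one end of a pair of indistinguishable numbers. Compound 3 `COC(=O)Nc1nc2cc(C(=O)NC(C)C)ccc2[nH]1` has not been measured. Its difference from compound 1 is isopropylamino in place of propoxy on a carbonyl carbon. Among the compounds with values here, no measured step bears on this change: the one step in hand alters the chain of the propoxy group only, while the carbonyl carbon and its neighbours stay as they are. Within the data shown here, there is no precedent for isopropylamino in place of propoxy on a carbonyl carbon. The expected step for compound 3 is therefore a 1.2-fold lower number from compound 1 to compound 3 (0.09 log units; within the scatter), small and of uncertain direction. Compound 3 is estimated at 6000 nM, expected to fall between 1500 nM and 25000 nM.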

Compound 3, half-maximal inhibitory concentration: 2000 nM
Compound 3: the middle estimate sits 3.0-fold (0.48 log units) above what was measured, within the range that was stated.
By their numbers in this assay, from the lowest: compound 3; then compounds 1 and 2 (each within the scatter of the next).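

In this assay, going by these compounds alone, the substituent on the carbonyl carbon is the first change to move the number: a 3.7-fold lower number from compound 1 to compound 3 (0.57 log units; beyond the scatter) follows isopropylamino in place of propoxy, a modest step but one beyond the scatter. Within the data shown here, the only earlier step, a 1.1-fold higher number from compound 1 to compound 2 (0.04 log units; within the scatter), lies within the scatter and gave no sign that any part of these structures affects the read-out, so propoxycarbonyl to isopropylcarbamoyl is the one change so far with a readable effect. No measured evidence bears on why this change lowers the number.

The compounds shown do not separate the nitrogen link from the branching of the chain, since isopropoxy and propylamino on the same carbonyl carbon are absent from them. On these data alone, how a carboxylic acid, a primary amide or a longer chain at this carbon would read also remains open.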